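The source may report more compounds than this note shows. Statements on the series, on what has been measured and on what is new or still open speak of the compounds shown alone.

Working notes on the series, measured in a functional assay on HeLa cells (Homo sapiens) for antiproliferative activity, read by MTT assay, with a stated time of 24 h; on this read-out higher numbers stand for weaker inhibition and lower numbers for stronger inhibition:

compound 1 `Cc1ccc(-c2nn(-c3ccccc3)cc2-c2nc3ccccc3[nH]2)cc1`: 4950 nM
compound 2 `FC(F)(F)c1ccc(-c2nn(-c3ccccc3)cc2-c2nc3ccccc3[nH]2)cc1`: 4670 nM
compound 3 `COc1ccc(S(=O)(=O)n2c(-c3cn(-c4ccccc4)nc3-c3ccc(F)cc3)nc3ccccc32)cc1`: 390 nM

Compound 2 at 4670 nM sits within the scatter of compound 1 and well above compound 3 on the numbers of this assay. The next structure is compound 4 `O=[N+]([O-])c1ccc(S(=O)(=O)n2c(-c3cn(-c4ccccc4)nc3-c3ccc(C(F)(F)F)cc3)nc3ccccc32)cc1`, reached by the change ((4-nitrophenyl)sulfonyl in place of hydrogen on an aromatic nitrogen), which is (4-nitrophenyl)sulfonyl in place of hydrogen on an aromatic nitrogen.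

Going by the values given here, the only measured step, a 1.1-fold lower number from compound 1 to compound 2 (0.03 log units; within the scatter), is trifluoromethyl in place of methyl on an aromatic carbon. It is small and does not touch that nitrogen, so it gives no size for this change. Among the compounds with values here, compound 3 is the one measured compound with a sulfonyl group on that nitrogen, but it also differs from compound 2 elsewhere. Within the data shown here, no measured step isolates the change.

Among the measured compounds shown here, with compound 3 at 390 nM as the only guide, a step to a lower number, beyond the scatter, is expected. The estimated step is an 8.5-fold lower number from compound 2 to compound 4 (0.93 log units; beyond the scatter) and remains uncertain, resting on that single comparison. For compound 4 the estimate is 550 nM, with an expected range from 170 nM to 1800 nM in this assay.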

Compound 4, half-maximal inhibitory concentration: 950 nM
Beside the measured number, compound 4's estimate is 1.7-fold (0.24 log units) below it; the measured number falls inside the stated range.
By their numbers in this assay, from the lowest: compound 3; then compound 4; then compounds 2 and 1 (each within the scatter of the next).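

In this assay, going by these compounds alone, (4-nitrophenyl)sulfonyl in place of hydrogen on the aromatic nitrogen gives a 4.9-fold lower number from compound 2 to compound 4 (0.69 log units; beyond the scatter), a modest step and the first that isolates a change at this position. Within the data shown here, compound 3 also carries a sulfonyl group on that nitrogen but differs from compound 2 elsewhere as well, so the earlier compounds gave no size for this change; it now shows that a large arylsulfonyl group on this nitrogen, with the trifluoromethyl group kept in place, goes with a lower number rather than a loss of inhibition. Nothing available here accounts for the size or direction of the step.

The compounds shown leave open whether the step belongs to the sulfonyl link or to the 4-nitrophenyl ring, as this nitrogen has only one single-change step to read. Also open, as far as these compounds go, is whether an acetyl or benzyl group on the same nitrogen, or an amine in place of the nitro group on the ring, would give a step of similar size, and whether the step holds with methyl in place of trifluoromethyl.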